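The source may hold more compounds than are shown below. What is called first, only, known or untested is meant among the compounds shown, and "the series" means these compounds.

In a functional assay on MCF7 cells (Homo sapiens) for antiproliferative activity, read by CCK-8 assay, with a stated time of 72 h (on this read-out lower numbers stand for stronger inhibition and higher numbers for weaker inhibition), two compounds sharing one core have been measured so far. Compound 1 (`Cc1cc(Nc2cc(N3CCN(C)CC3)nc(Nc3ccc(S(N)(=O)=O)cc3)n2)n[nH]1`), which carries a sulfamoyl group, gives 2680 nM. Compound 2 (`Cc1cc(Nc2cc(N3CCN(C)CC3)nc(Nc3ccc([N+](=O)[O-])cc3)n2)n[nH]1`), which carries a nitro group in its place, gives 424 nM, the lower of the two numbers. The next compound, compound 3 (`Cc1cc(Nc2cc(N3CCN(C)CC3)nc(Nc3ccc(Cl)cc3)n2)n[nH]1`), has chloro in place of nitro on an aromatic carbon. Within the data shown here, only one measured step bears on this change, a 6.3-fold lower number from compound 1 to compound 2 (0.80 log units; beyond the scatter), a modest step at the same place that lies beyond the scatter. Among the measured compounds shown here, it shows that a swap here can move the number, but no chloro compound has been measured to set a direction. A small rise in this assay, probably within the scatter, is therefore expected. Compound 3 is estimated at 600 nM, with an expected range of 200 nM to 1800 nM. That estimate means an expected 1.4-fold higher number from compound 2 to compound 3 (0.15 log units; within the scatter).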

Compound 3, half-maximal inhibitory concentration: 840 nM
Compound 3: the middle estimate sits 1.4-fold (0.15 log units) below what was measured; measured number inside the range.
By their numbers in this assay, from the lowest: compounds 2 and 3 (each within the scatter of the next); then compound 1.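

In this assay, chloro in place of nitro on the aromatic carbon gives a 2.0-fold higher number from compound 2 to compound 3 (0.30 log units; within the scatter), so this read-out does not separate these two groups at this position. Chloro in place of sulfamoyl gives a 3.2-fold lower number from compound 1 to compound 3 (0.50 log units; beyond the scatter), which shows that the lower number relative to compound 1 is not tied to nitro alone: both replacements shown, nitro and chloro, lie beyond the scatter from the sulfamoyl compound. Nothing available here explains why these groups match or differ.

The compounds shown leave open whether the number at this position tracks any particular feature of the group, as only three groups have been compared on the shared core. An amine, a methoxy group or a carboxylic acid on the same carbon could show whether compound 1 stands alone or marks one end of a wider spread in this assay.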